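The source may report more compounds than this note shows. Statements on the series, on what has been measured and on what is new or still open speak of the compounds shown alone.

Measured compounds in a functional assay on MCF7 cells (Homo sapiens) for cytotoxicity, read by MTT assay, with a stated time of 48 h; on this read-out lower numbers stand for stronger inhibition and higher numbers for weaker inhibition:
compound 1, `C=C1CC[C@@H](C(C)C)[C@]12CC=C(C=O)CC2`, where compound 1 gives 210000 nM
compound 2, `C=C1CCC[C@]2(C)CCC(c3cn(-c4ccc(OC)cc4)nn3)=CC[C@@]12C`, where compound 2 gives 118000 nM

The two numbers lie within the usual scatter of each other, so compound 2 stands apart from compound 1 in no secure way. Compound 3 `C=C1CCC[C@]2(C)CCC(c3cn(-c4ccc(C)cc4)nn3)=CC[C@@]12C` differs from compound 2 by methyl in place of methoxy on an aromatic carbon. For the measured compounds named here, no pair of measured compounds shows this change, so there is no measured step to lean on; a swap of this kind is expected to move the number little, if at all, beyond the scatter. The step of a 1.0-fold higher number from compound 2 to compound 3 (0.01 log units; within the scatter) is therefore estimated as flat. Compound 3 is expected to give about 120000 nM, with a range from 50000 nM to 300000 nM.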

Compound 3, half-maximal inhibitory concentration: 54900 nM
Estimate against measurement, compound 3: 2.2-fold (0.34 log units) above, and the stated range covers the measured number.
By their numbers in this assay, from the lowest: compound 3; then compounds 2 and 1 (each within the scatter of the next).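

In this assay the change from 4-methoxyphenyl to 4-methylphenyl gives a 2.1-fold lower number from compound 2 to compound 3 (0.33 log units; beyond the scatter) and so shows that the group on this aromatic carbon, para to a large group, can shift the number beyond the scatter. Of these two groups, methyl goes with the stronger inhibition at this position, though the step is modest. No measurement at hand explains the direction of this step.

On these data alone, whether an amine, a carboxylic acid or a longer chain at this position would lower the number further remains open. So does the effect of a chlorine atom there.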